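Notes on compound 4: acetyl replaced by dimethylamino

This account rests on a few compounds, and the source may have more. Where it says the series, first, only, none or still open, it means among the compounds named here.

Measured so far:
compound 1 `COc1cc(C)cc(-c2c(-c3ccnc(-c4ccc(C(C)=O)cc4)c3)cnn2CC#N)c1` gives 87%
compound 2 `COc1cc(C)cc(-c2nn(CC#N)cc2-c2ccnc(-c3ccc(N(C)C)cc3)c2)c1` gives 8%
compound 3 `Cc1cc(O)cc(-c2nn(CC#N)cc2-c2ccnc(-c3ccc(N(C)C)cc3)c2)c1` gives 90%

In a functional assay on NCI-H460 cells (Homo sapiens) for cytotoxicity, read by sulforhodamine B assay, with a stated time of 48 h, tested at 100 nM (on this read-out higher numbers stand for a weaker effect at the one concentration tested and lower numbers for a stronger effect), compound 1 stands second highest of the three numbers, within the scatter of compound 3 and far above compound 2. Compound 4 `COc1cc(C)cc(-c2c(-c3ccnc(-c4ccc(N(C)C)cc4)c3)cnn2CC#N)c1` differs from compound 1 by dimethylamino in place of acetyl on an aromatic carbon. Within the data shown here, no measured step covers this exact change: the one step on record, a number 82 percentage points higher from compound 2 to compound 3 (beyond the scatter), concerns the oxygen substituent and not the acetylphenyl group. Compound 2 carries the same 4-(dimethylamino)phenyl group and gives a low number, but its groups sit differently on the shared core, so it is only a loose pointer. A sizeable drop is nevertheless expected, a number 47 percentage points lower from compound 1 to compound 4 (beyond the scatter), with wide uncertainty. Compound 4 is estimated at 40%, between 5% and 85%.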

Compound 4, a percentage reported as activity, at one concentration (the size of the read-out at that concentration, not a potency): -43%
The estimate for compound 4 lay 83 percentage points above the measured number, outside the stated range (below it).
By their numbers in this assay, from the lowest: compound 4; then compound 2; then compounds 1 and 3 (each within the scatter of the next).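

On the core of compound 1, the exchange of 4-acetylphenyl for 4-(dimethylamino)phenyl is enough to shift the read-out in this assay: a number 130 percentage points lower from compound 1 to compound 4 (beyond the scatter). The earlier step concerned only the oxygen substituent; this one shows that the read-out also answers strongly to the group on this aromatic carbon, with compound 4 at -43%, a value below zero. Nothing at hand bears on the cause of this step.

On these data alone, it remains open whether a primary amine or a carboxylic acid at this place would give a number like that of compound 4. Also open, as far as these compounds go, is whether the same exchange would give a step of similar size with a hydroxyl group in place of the methoxy group on the core of compound 4.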